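Aryl swap on the ring nitrogen: compound 3

A few compounds are considered here, and "the series" means these few. Any claim that something is new, unique, unknown or untested is made for them only; others in the source may bear on it.

Measured so far:
compound 1 `CC(C)(C)C1=NN(c2ccc(F)cc2)C(c2ccc(O)cc2)C1` gives 95.5%
compound 2 `CC(C)(C)C1=NN(c2cccc(F)c2)C(c2ccc(O)cc2)C1` gives 98.1%

Both measured compounds share one core and differ only in the aryl group on the ring nitrogen. In an assay on isolated protein for inhibition of protein kinase C zeta type (Homo sapiens), with a stated time of 4 min, tested at 62.5 uM (a lower number here means less inhibition, a higher number more inhibition at the concentration tested (going by the name of the read-out)), compound 1 gives 95.5% and compound 2 gives 98.1%. Within the data shown here, the single measured step is a number 2.6 percentage points higher from compound 1 to compound 2 (within the scatter), so the two numbers lie within the usual scatter of each other and the inhibition in this assay is level between the pair; compound 2 merely holds the larger of the two numbers, both of them high on the scale at the concentration tested.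

Compound 3 `CC(C)(C)C1=NN(c2ccccc2Cl)C(c2ccc(O)cc2)C1` is not yet measured. It differs from compound 2 as follows: 2-chlorophenyl in place of 3-fluorophenyl on an amine nitrogen in a ring. Among the measured compounds shown here, the only step that bears on this change is the one from compound 1 to compound 2, a shift of a halogen on the same aryl group, and it was within the scatter. With both measured values near the top of the scale, no step beyond the scatter is expected in this assay for compound 3. Compound 3 is therefore expected to give about 95%, with a range of 85% to 100%. The estimated step from compound 2 is a number 3.1 percentage points lower from compound 2 to compound 3 (within the scatter), which is expected to remain within the scatter.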

Compound 3, a percentage reported as inhibition, at one concentration (the size of the read-out at that concentration, not a potency): 57.1%
Compound 3: the middle estimate sits 37.9 percentage points above what was measured, and the stated range ends above it.
By their numbers in this assay, from the lowest: compound 3; then compounds 1 and 2 (each within the scatter of the next).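

In this assay the aryl group on the ring nitrogen turns out to be sensitive to the change: the step is a number 41 percentage points lower from compound 2 to compound 3 (beyond the scatter), and against the other fluorinated analogue it is a number 38.4 percentage points lower from compound 1 to compound 3 (beyond the scatter), whereas the exchange of 4-fluorophenyl for 3-fluorophenyl gave only a number 2.6 percentage points higher from compound 1 to compound 2 (within the scatter). The drop comes with no change in what is counted for the group, since 3-fluorophenyl and 2-chlorophenyl have the same number of heavy atoms and the same donor and acceptor counts, so these counts do not separate the high and low numbers in this set. Nothing at hand bears on the reason for the drop.

Because halogen identity and halogen position change together in this step, the compounds shown cannot assign the drop to either one. Chlorine at the positions held by fluorine in compound 1 and compound 2, fluorine at the position held by chlorine in compound 3, and an unsubstituted phenyl or a methyl-substituted phenyl on the same nitrogen would each help to separate the two, and the single tested concentration leaves potency itself open.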